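This account rests on a few compounds, and the source may have more. Where it says the series, first, only, none or still open, it means among the compounds named here.

Measured in a functional assay on A549 cells (Homo sapiens) for cytotoxicity, read by MTT assay, with a stated time of 72 h; a lower number here means a stronger inhibitor, a higher number a weaker inhibitor:
compound 1 `COc1ccc(/C=C2\CCC/C(=C\c3ccccc3Cl)C2=O)cc1OC`: > 20000 nM
compound 2 `COc1ccc(/C=C2\CCC/C(=C\c3cccc(Cl)c3)C2=O)cc1OC`: 11000 nM
compound 3 `COc1ccc(/C=C2\CCC/C(=C\c3ccccc3Br)C2=O)cc1OC`: > 20000 nM

Compound 3 stands at the limit of > 20000 nM in this assay, at which 2 of the 3 values shown sit. Its entry, > 20000 nM, is a limit and not a number. The entry for compound 1 is a limit as well. Only compound 2 has a number, 11000 nM.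

The next structure is compound 4 `COc1ccc(/C=C2\CCC/C(=C\c3cccc(Br)c3)C2=O)cc1OC`. The change is 3-bromophenyl in place of 2-bromophenyl on a double-bonded chain carbon bound to a double-bonded ring carbon, with 3-bromophenyl in place of 2-bromophenyl on a double-bonded chain carbon bound to a double-bonded ring carbon.

Going by the values given here, the closest precedent is the same move in the chloro pair, an at least 1.8-fold lower number from compound 1 to compound 2 (0.25 log units; that floor lies within the scatter). The other two steps bear on the exchange of halogen: a step that the two limits leave unreadable from compound 1 to compound 3, and an at least 1.8-fold higher number from compound 2 to compound 3 (0.25 log units; that floor lies within the scatter). Among the compounds with values here, no measured pair shows the effect of bromo for chloro as a number. A lower number is therefore expected for the 3-bromophenyl in this assay, of a size left open by the limit on compound 3. The expected step is an at least 2.0-fold lower number from compound 3 to compound 4 (0.30 log units; that floor lies within the scatter). The best anchor is compound 2 at 11000 nM, and a value close to it is expected. The estimate for compound 4 is 10000 nM, with an expected range from 5000 nM to 20000 nM.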

Compound 4, half-maximal inhibitory concentration: 12800 nM
The estimate for compound 4 lay 1.3-fold (0.11 log units) below the measured number; the range from low to high includes it.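

In this assay, 3-bromophenyl in place of 2-bromophenyl gives an at least 1.5-fold lower number from compound 3 to compound 4 (0.19 log units; that floor lies within the scatter), which runs the same way as the chloro pair with an at least 1.8-fold lower number from compound 1 to compound 2 (0.25 log units; that floor lies within the scatter), although neither floor clears the scatter. Going by these compounds alone, the first readable exchange of halogen is a 1.2-fold higher number from compound 2 to compound 4 (0.07 log units; within the scatter), so this read-out does not separate the 3-chlorophenyl and 3-bromophenyl compounds. The step that carries both changes, an at least 1.5-fold lower number from compound 1 to compound 4 (0.19 log units; that floor lies within the scatter), gives no firmer reading, and the 2-chlorophenyl and 2-bromophenyl compounds remain limits and not numbers: the limit of > 20000 nM in this assay, at which 2 of the 4 values shown sit.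

As far as these compounds go, how far the 2-chlorophenyl and 2-bromophenyl compounds lie from the 3-chlorophenyl and 3-bromophenyl compounds remains open, as does any difference between the two halogens in the 2-substituted pair. Also open, from the compounds shown here alone, is whether an amine or a carboxylic acid in place of the halogen on this aromatic carbon would move the number beyond the scatter, on a shared core that so far shows only chloro and bromo.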